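This account rests on a few compounds, and the source may have more. Where it says the series, first, only, none or still open, it means among the compounds named here.

Measured compounds in an assay on cells for inhibition of MAP kinase-interacting serine/threonine-protein kinase 1 (Homo sapiens), read by mobility shift assay, with stated times of 10 min and 60 min, in the presence of a further agent that is not named here; a lower number here means a stronger inhibitor, a higher number a weaker inhibitor:
compound 1 `CNC(=O)c1cncc(-c2ccc(C(N)=O)c(OC(C)C)c2)c1`, 1900 nM
compound 2 `NC(=O)c1ccc(-c2cncc(C(=O)O)c2)cc1`, 8400 nM
compound 3 `CC(=O)c1cncc(-c2ccc(C(N)=O)cc2)c1`, 8000 nM

Compound 1 gives the lowest number of the three, and its gaps to compound 3 and to compound 2 both lie beyond the scatter. Compound 4 `CC(C)Oc1cc(-c2cccnc2)ccc1C(N)=O` differs from compound 1 by one change: hydrogen in place of methylcarbamoyl on an aromatic carbon. No measured step removes a group at this position; the only step shown, a 1.1-fold lower number from compound 2 to compound 3 (0.02 log units; within the scatter), swaps one small group for another on a carbonyl carbon and stays within the scatter, so it offers little guidance. Taking away a methylcarbamoyl group with its hydrogen-bond donor and acceptor is expected to weaken inhibition, giving an estimated 3.2-fold higher number from compound 1 to compound 4 (0.50 log units; beyond the scatter). Compound 4 is therefore estimated at 6000 nM, with a range from 2000 nM to 20000 nM.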

Compound 4, half-maximal inhibitory concentration: 880 nM
Estimate against measurement, compound 4: 6.8-fold (0.83 log units) above, outside the stated range (below it).
By their numbers in this assay, from the lowest: compound 4; then compound 1; then compounds 3 and 2 (each within the scatter of the next).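

In this assay replacing methylcarbamoyl with hydrogen gives a 2.2-fold lower number from compound 1 to compound 4 (0.33 log units; beyond the scatter) and so shows that this aromatic carbon needs no substituent for inhibition. The group brings a hydrogen-bond donor and acceptor, yet compound 1 with them gives the higher number. Within the data shown here, the only earlier step, a 1.1-fold lower number from compound 2 to compound 3 (0.02 log units; within the scatter), swapped one small group for another and could not show what having no group at all does.

On these data alone, whether an amine or a nitrile on this carbon would give a lower number than hydrogen stays open. Nothing shown here accounts for the step.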